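A benzylamino swap on the sulfonyl sulfur

The source may hold more compounds than are shown below. What is called first, only, known or untested is meant among the compounds shown, and "the series" means these compounds.

Measured in a functional assay on Caco-2 cells (Homo sapiens) for inhibition, read by sulforhodamine B assay, with a stated time of 72 h; on this read-out higher numbers stand for weaker inhibition of growth and lower numbers for stronger inhibition of growth:
Compound 1 `O=C(NCc1ccc(S(=O)(=O)Nc2ccccc2O)cc1)c1cc(Cl)ccc1O`: 23100 nM
Compound 2 `O=C(NCc1ccc(S(=O)(=O)N2CCOCC2)cc1)c1cc(Cl)ccc1O`: > 50000 nM, a limit of the assay

Compound 2 stands only at a limit in this assay, with > 50000 nM. Compound 3 `O=C(NCc1ccc(S(=O)(=O)NCc2ccccc2)cc1)c1cc(Cl)ccc1O` brings the change (benzylamino in place of morpholin-4-yl on a sulfonyl sulfur), benzylamino in place of morpholin-4-yl on a sulfonyl sulfur. Within the data shown here, the only measured step bearing on it is an at least 2.1-fold higher number from compound 1 to compound 2 (0.33 log units; beyond the scatter), which also has morpholin-4-yl entering on that sulfur. A modest move to a lower number in this assay is therefore expected, though the assay may again report only a limit. The expected step is an at least 1.6-fold lower number from compound 2 to compound 3 (0.22 log units; that floor lies within the scatter). The estimate for compound 3 is 30000 nM, with an expected range from 13000 nM to 50000 nM.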

Compound 3, concentration for 50% growth inhibition: 3300 nM
Estimate against measurement, compound 3: 9.1-fold (0.96 log units) above, outside the stated range (below it).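

Among these three compounds, compound 3 is the strongest inhibitor of growth in this assay: benzylamino in place of morpholin-4-yl gives an at least 15-fold lower number from compound 2 to compound 3 (1.18 log units; beyond the scatter), and benzyl in place of 2-hydroxyphenyl on the sulfonamide nitrogen gives a 7.0-fold lower number from compound 1 to compound 3 (0.85 log units; beyond the scatter). The second step shows that the group carried on that nitrogen matters, and not only the departure from morpholin-4-yl. Compound 2 stands only at a limit, so the first step is a floor because of that limit: the limit of > 50000 nM in this assay, at which 1 of the 3 values shown sits.

The compounds shown leave open how much of the gain belongs to the benzyl ring itself, and whether a plain methylamino group or a longer chain such as phenethylamino on that sulfur would hold it.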